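The source may hold more compounds than are shown below. What is called first, only, known or untested is meant among the compounds shown, and "the series" means these compounds.

Measured in an ADME assay on S9 fraction from liver (Rattus norvegicus) for metabolic stability, read by LC-MS, using NADPH, with a stated time of 60 min, tested at 10 uM; a lower number here means that less of the compound is left, a higher number that more of the compound is left:
- compound 1 `CCC(O)Cc1cc(-c2ccnc3[nH]nc(C(F)(F)F)c23)cc(C2(C#N)CC2)c1`: 17%
- compound 2 `CC(C)C(O)Cc1cc(-c2ccnc3[nH]nc(C(F)(F)F)c23)cc(C2(C#N)CC2)c1`: 19%

In this assay, compound 2 gives 19%, which stands within the scatter of compound 1, so both compounds sit at about the same low level. The next compound, compound 3 `N#CC1(c2cc(CC(O)C3CC3)cc(-c3ccnc4[nH]nc(C(F)(F)F)c34)c2)CC1`, differs from compound 2 by cyclopropyl in place of isopropyl on a saturated chain carbon bound to an oxygen on a saturated carbon and a saturated chain carbon. Among the measured compounds shown here, no measured pair shows this exchange. For the measured compounds named here, the only measured step that bears on it is a number 2 percentage points higher from compound 1 to compound 2 (within the scatter), where methyl replaced hydrogen within the same side chain. That step is small, so only a small shift is to be expected here. The expected result is a number 2 percentage points higher from compound 2 to compound 3 (within the scatter), with no change beyond the scatter anticipated. For compound 3 the estimated value is 21%, with an expected range of 11% to 35%.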

Compound 3, percent of the compound remaining: 0%
The estimate for compound 3 lay 21 percentage points above the measured number; measured number outside the range, below it.
By their numbers in this assay, from the lowest: compound 3; then compounds 1 and 2 (each within the scatter of the next).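

In this assay, the earlier pair suggested that this place, a saturated chain carbon bound to an oxygen on a saturated carbon and a saturated chain carbon, made little difference, but the exchange of isopropyl for cyclopropyl gives a number 19 percentage points lower from compound 2 to compound 3 (beyond the scatter), and the exchange of ethyl for cyclopropyl gives a number 17 percentage points lower from compound 1 to compound 3 (beyond the scatter). The group at this place can therefore change the result beyond the scatter, even when the heavy-atom count stays the same, as it does between isopropyl and cyclopropyl. Nothing available here explains the fall seen with the three-membered ring.

The compounds shown leave open whether the fall belongs to cyclopropyl alone or would also appear with a cyclobutyl ring. They also leave open how a tert-butyl group at this place would compare with the open chains.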